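The compounds below may be only part of what the source reports. "The series", "measured", "known", "first", "only" and "open" are said of these compounds alone.

Compound 1 `O=C1C(Nc2ccccc2F)=CC(=O)c2c1nc1n2[C@H]2OC[C@@H](O)[C@H]2OC1` gives 2000 nM in a functional assay on MGC-803 cells (Homo sapiens) for inhibition, read by sulforhodamine B assay (a lower number here means a stronger inhibitor, a higher number a weaker inhibitor), and compound 3 `CCc1ccc(NC2=CC(=O)c3c(nc4n3[C@H]3OC[C@@H](O)[C@H]3OC4)C2=O)cc1` gives 1110 nM there, so the two sit level within the scatter. Compound 2 `O=C1C(NC2CCCC2)=CC(=O)c2c1nc1n2[C@H]2OC[C@@H](O)[C@H]2OC1` gives only a limit (> 16000 nM). Compound 4 `Cc1ccc(NC2=CC(=O)c3c(nc4n3[C@H]3OC[C@@H](O)[C@H]3OC4)C2=O)cc1` differs from compound 3 by one change (hydrogen in place of methyl on a saturated chain carbon bound to an aromatic carbon): hydrogen in place of methyl on a saturated chain carbon bound to an aromatic carbon, turning 4-ethylphenyl into 4-methylphenyl. Among the measured compounds shown here, no measured step makes this exact change. The closest guide is a 1.8-fold lower number from compound 1 to compound 3 (0.26 log units; within the scatter) between two phenyl groups, which stayed within the scatter. The large at least 14-fold lower number from compound 2 to compound 3 (1.15 log units; beyond the scatter) involved cyclopentyl, which compound 4 does not carry. A step within the scatter is therefore expected in this assay (a 1.2-fold higher number from compound 3 to compound 4 (0.07 log units; within the scatter)). The estimated value for compound 4 is 1300 nM (expected range from 550 nM to 3000 nM).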

Compound 4, half-maximal inhibitory concentration: 1550 nM
Estimate against measurement, compound 4: 1.2-fold (0.08 log units) below; the measured number falls inside the stated range.
By their numbers in this assay, from the lowest: compounds 3, 4 and 1 (each within the scatter of the next). At a limit, above all of these: compound 2.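

In this assay, 4-ethylphenyl and 4-methylphenyl read alike (a 1.4-fold higher number from compound 3 to compound 4 (0.15 log units; within the scatter)), so shortening this chain by one carbon does not move the number beyond the scatter. Compound 4 also sits level with the 2-fluorophenyl compound (a 1.3-fold lower number from compound 1 to compound 4 (0.11 log units; within the scatter)), yet stands well apart from the cyclopentyl compound (an at least 10-fold lower number from compound 2 to compound 4 (1.01 log units; beyond the scatter)), confirming that gap with a second 4-substituted phenyl group. Compound 2 gives a limit, not a number: the limit of > 16000 nM in this assay, at which 1 of the 4 values shown sits.

Going by these compounds, whether this level reading would hold for a longer chain such as butyl, or for a carboxylic acid or an amine in the same place, stays open. Plain phenyl also remains untested among the compounds shown.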